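The source may report more compounds than this note shows. Statements on the series, on what has been measured and on what is new or still open speak of the compounds shown alone.

Measured compounds:
- compound 1, `Nc1sc(-c2ccc([N+](=O)[O-])cc2)c(-c2cccc(C(F)(F)F)c2)c1C(=O)c1ccccc1`, gives in a functional assay on CHO-K1 cells for agonist activity at adenosine receptor A1 (Homo sapiens), read by GTPgammaS binding (a higher number here means that more compound is needed for the effect, a lower number that less compound is needed), the limit > 10 uM
- compound 2, `Nc1sc(-c2ccc(Cl)cc2)c(-c2cccc(C(F)(F)F)c2)c1C(=O)c1ccccc1`, gives in this assay the limit > 10 uM
- compound 3, `CCOC(=O)c1c(N)sc(-c2ccc([N+](=O)[O-])cc2)c1-c1cccc(C(F)(F)F)c1`, gives in this assay the limit > 10 uM

All three values are limits of the assay, not numbers. The step from compound 1 to compound 2 is therefore a step that the two limits leave unreadable from compound 1 to compound 2; the change made there is chloro in place of nitro on an aromatic carbon. The cores of compound 1 and compound 3 differ by ethoxy in place of phenyl on a carbonyl carbon, and that step is likewise a step that the two limits leave unreadable from compound 1 to compound 3. What the three compounds share is the limit of > 10 uM in this assay, at which 3 of the 3 values shown sit.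

Compound 4, `CCOC(=O)c1c(N)sc(-c2ccc(Cl)cc2)c1-c1cccc(C(F)(F)F)c1`, has not been measured in this assay. It differs from compound 3 by chloro in place of nitro on an aromatic carbon, which is the same change that leads from compound 1 to compound 2, with the same place around it. Since that change, where it was measured, gave a step that the two limits leave unreadable from compound 1 to compound 2, and since compound 3 itself stands at the limit > 10 uM, the step from compound 3 to compound 4 is expected to be a step that the limit leaves unreadable from compound 3 to compound 4, with its size no more readable than the earlier one. Compound 4 is thus expected to give about 20 uM, in the range from 5 uM to 100 uM, most likely again only as a limit.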

Compound 4, concentration for half-maximal effect: 6.6 uM
Compound 4: middle estimate off by 3.0-fold (0.48 log units), on the high side; measured number inside the range.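

In this assay, chloro in place of nitro on the core of compound 3 gives an at least 1.5-fold lower number from compound 3 to compound 4 (0.18 log units; that floor lies within the scatter), and ethoxy in place of phenyl on a carbonyl carbon, with the 4-chlorophenyl kept, gives an at least 1.5-fold lower number from compound 2 to compound 4 (0.18 log units; that floor lies within the scatter). Compound 4 is thus the only one of the four compounds to give a number rather than a limit, but both steps are floors, so their true sizes stay unknown and neither is shown to lie beyond the scatter. The data do not show whether the change carries from one core to the other, since its step on the core of compound 1 cannot be read, nor can the other steps among the limits, because the values there stop at a single limit of the assay: the limit of > 10 uM in this assay, at which 3 of the 4 values shown sit.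

The compounds shown leave open whether bromo or methoxy in the place of chloro would give a number in this assay, and whether the 4-chlorophenyl step would be readable on the core of compound 1 at all. They also leave open what a carboxylic acid, an amide or a longer chain in place of the ethyl ester would give on the core of compound 4.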